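Inverting one ring stereocentre in a nucleoside adenosine ligand

The source may report more compounds than this note shows. Statements on the series, on what has been measured and on what is new or still open speak of the compounds shown alone.

Measured compounds:
compound 1, `OC[C@@]1(O)CO[C@@H](n2cnc3c(NCc4cccc(Cl)c4)ncnc32)[C@@H]1O`: 10%
compound 2, `COc1ccc(Cl)cc1CNc1ncnc2c1ncn2[C@@H]1OC[C@@](O)(CO)[C@H]1O`: 13%
compound 3, `OC[C@]1(O)CO[C@@H](n2cnc3c(NCc4cccc(I)c4)ncnc32)[C@@H]1O`: 35%

In an assay on CHO cells for displacement of a labelled ligand from adenosine receptor A1 (Homo sapiens), tested at 10 uM (a lower number here means less inhibition, a higher number more inhibition at the concentration tested (going by the name of the read-out)), compound 2 gives 13%, the second highest of the three numbers. Its nearest neighbour is compound 1, whose value lies within the scatter of that of compound 2; compound 3 lies furthest away, with a step of a number 22 percentage points higher from compound 2 to compound 3 (beyond the scatter), which is beyond the scatter.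

Compound 4, `COc1ccc(Cl)cc1CNc1ncnc2c1ncn2[C@@H]1OC[C@](O)(CO)[C@H]1O`, is not yet measured. It differs from compound 2 as follows: the two compounds have the same atoms and bonds and differ only in configuration as drawn: 1 of 3 stereo elements differ; a stereocentre at a saturated ring carbon is drawn S in compound 2 and R in compound 4

Within the data shown here, the only step measured so far, a number 22 percentage points higher from compound 2 to compound 3 (beyond the scatter), exchanges the group on the saturated chain carbon and leaves every stereocentre untouched, so it says nothing about an inversion at a saturated ring carbon. Compounds 1 and 3 differ from each other in two places at once, so their values cannot be separated into a stereo part and a group part. Without a measured inversion of this kind, compound 4 is expected to give 12%, in the range 0% to 35%, that is an expected step of a number 1 percentage points lower from compound 2 to compound 4 (within the scatter), not beyond the scatter.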

Compound 4, a percentage reported as inhibition, at one concentration (the size of the read-out at that concentration, not a potency): 12%
For compound 4 middle estimate and measured number coincide at the digits printed; low and high end bracket the measured number.
By their numbers in this assay, from the lowest: compounds 1, 4 and 2 (each within the scatter of the next); then compound 3.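

Among these compounds, this pair gives the first direct reading of an inversion at the saturated ring carbon, and it can be read as the inversion alone because of how the structures relate: the fact that compounds 2 and 4 differ only in the configuration as drawn. In this assay, the change from S to R gives a step of a number 1 percentage points lower from compound 2 to compound 4 (within the scatter), so with the 5-chloro-2-methoxyphenyl group in place, this position shows no change that stands out from the scatter. The step of a number 2 percentage points higher from compound 1 to compound 4 (within the scatter), which brings in methoxy in place of hydrogen on an aromatic carbon, also stays within the scatter.

From the compounds shown here alone, it remains open whether the same inversion would leave the number unchanged with the 3-iodophenyl group of compound 3, which gives 35%. Going by these compounds, it is also open how an amine on the saturated ring carbon would read in this assay.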